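From 3-methoxyphenyl to 4-bromophenyl on an aromatic nitrogen

This account rests on a few compounds, and the source may have more. Where it says the series, first, only, none or still open, it means among the compounds named here.

Measured in a functional assay on HT-29 cells (Homo sapiens) for antiproliferative activity, read by MTT assay, with a stated time of 72 h; on this read-out higher numbers stand for weaker inhibition and lower numbers for stronger inhibition:
Compound 1 `COc1cc(-c2nccn2C)cc(OC)c1OC`: > 100000 nM, a limit of the assay
Compound 2 `COc1cc(-c2nccn2-c2ccc(C)cc2)cc(OC)c1OC`: 1600 nM
Compound 3 `COc1cccc(-n2ccnc2-c2cc(OC)c(OC)c(OC)c2)c1`: 18900 nM

Compound 3 has the higher of the two actual numbers, and the value of compound 1 is only a limit. Compound 4 `COc1cc(-c2nccn2-c2ccc(Br)cc2)cc(OC)c1OC` differs from compound 3 by 4-bromophenyl in place of 3-methoxyphenyl on an aromatic nitrogen, with 4-bromophenyl in place of 3-methoxyphenyl on an aromatic nitrogen. Replacing methyl at that nitrogen gave an at least 62-fold lower number from compound 1 to compound 2 (1.79 log units; beyond the scatter) and an at least 5.2-fold lower number from compound 1 to compound 3 (0.72 log units; beyond the scatter). The closest guide is compound 2, which bears 4-methylphenyl there, and the measured step is a 12-fold higher number from compound 2 to compound 3 (1.07 log units; beyond the scatter). A large step to a lower number is therefore expected, in the estimated form a 16-fold lower number from compound 3 to compound 4 (1.20 log units; beyond the scatter). The estimate for compound 4 is 1200 nM, with an expected range of 250 nM to 6000 nM.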

Compound 4, half-maximal inhibitory concentration: 7700 nM
For compound 4 the middle estimate is 6.4-fold (0.81 log units) below the measured one; the measured number lies above the stated range.
By their numbers in this assay, from the lowest: compound 2; then compound 4; then compound 3. At a limit, above all of these: compound 1.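

In this assay, the 4-bromophenyl group gives a 2.5-fold lower number from compound 3 to compound 4 (0.39 log units; beyond the scatter), and with bromo in place of methyl on the aromatic carbon of that ring there is a 4.8-fold higher number from compound 2 to compound 4 (0.68 log units; beyond the scatter). At this nitrogen, then, the group carried by the phenyl ring changes the number, not just the presence of the ring. The further step, an at least 12-fold lower number from compound 1 to compound 4 (1.11 log units; beyond the scatter), is bounded only by a limit, not a number: the limit of > 100000 nM in this assay, at which 1 of the 4 values shown sits.

The compounds shown leave open how an amine or a carboxylic acid on that phenyl ring would read, and how a longer chain at the nitrogen would compare.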